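The source may report more compounds than this note shows. Statements on the series, on what has been measured and on what is new or still open speak of the compounds shown alone.

The measured compounds are these. Compound 1, `CC(=O)Nc1cccc(-c2ccc(C(=O)N(Cc3cccc(OCCCCCC(=O)O)c3)C(C)C)cc2)c1`, in an ADME assay on HEK293 cells (Homo sapiens) for cytotoxicity, read by CellTiter-Glo and resazurin assay, with a stated time of 72 h (a lower number here means that less compound is needed, a higher number that more compound is needed for the effect), gives > 26000 nM, which is a limit of the assay rather than a number. Compound 2, `CC(C)Oc1cccc(-c2ccc(C(=O)N(Cc3cccc(OCCCCCC(=O)O)c3)C(C)C)cc2)c1`, in this assay gives > 26000 nM, again a limit of the assay.

Compound 2 thus stands at a limit in this assay, and the two values shown both sit at that same point, (the limit of > 26000 nM in this assay, at which 2 of the 2 values shown sit). Among the measured compounds shown here, the one measured step, a step that the two limits leave unreadable from compound 1 to compound 2, cannot be read in size, as both of its ends are limits. Compound 3, `CC(C)N(Cc1cccc(OCCCCCC(=O)O)c1)C(=O)c1ccc(-c2cccc(Oc3ccccc3)c2)cc1`, differs from compound 2 in one place: phenyl in place of isopropyl on an oxygen on an aromatic ring. For the measured compounds named here, no measured step touches that oxygen; the single step between the measured compounds alters a different part of the shared core and is itself unreadable. No direction can therefore be expected for compound 3 in this assay beyond the scatter, and the most likely outcome is a further limit. The estimate for compound 3 in this assay is 30000 nM, within 10000 nM to 100000 nM, meaning an expected step that the limit leaves unreadable from compound 2 to compound 3.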

Compound 3, half-maximal effective concentration: > 18700 nM
Compound 3 ended at the assay's limit (the forecaster's own chance of this, stated with the estimate: 80%); the middle value is on the limit's open side.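

In this assay compound 3 gives > 18700 nM as a limit of the assay. Among the compounds shown here, with compound 1, compound 2 and compound 3 all at limits, no step among them can be read in size. The compounds shown leave open whether any change to the shared core would give a true number in this assay at all.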